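Adding a chloro group to compound 3

A few compounds are considered here, and "the series" means these few. Any claim that something is new, unique, unknown or untested is made for them only; others in the source may bear on it.

In a functional assay on NCI-H727 cells (Homo sapiens) for cytotoxicity, with a stated time of 48 h (a lower number here means a stronger inhibitor, a higher number a weaker inhibitor), compound 1 (`COc1cc(OC)c(C(=O)/C=C/c2ccccc2OC)c(OC)c1`) gives 4000 nM, compound 2 (`COc1cccc(/C=C/C(=O)c2c(OC)cc(OC)cc2OC)c1`) gives 8200 nM and compound 3 (`COc1cc(OC)c(C(=O)/C=C/c2ccccc2)c(OC)c1`) gives 11400 nM. Compound 3 therefore sits level with compound 2, and its number is higher than that of compound 1. Compound 4 (`COc1cc(OC)c(C(=O)/C=C/c2ccc(Cl)cc2)c(OC)c1`) has chloro in place of hydrogen on an aromatic carbon, para to a large group (chloro in place of hydrogen on an aromatic carbon). Among the measured compounds shown here, no measured compound carries chloro, so the only guides are the two steps that put hydrogen in place of methoxy: a 2.9-fold higher number from compound 1 to compound 3 (0.45 log units; beyond the scatter) is modest and beyond the scatter, while a 1.4-fold higher number from compound 2 to compound 3 (0.14 log units; within the scatter) stays within it. A small move towards a lower number is expected, a 1.6-fold lower number from compound 3 to compound 4 (0.21 log units; within the scatter). For compound 4 the estimate is 7000 nM, with an expected range of 2800 nM to 15000 nM.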

Compound 4, half-maximal inhibitory concentration: 6000 nM
Compound 4: middle estimate off by 1.2-fold (0.07 log units), on the high side, within the range that was stated.
By their numbers in this assay, from the lowest: compounds 1, 4, 2 and 3 (each within the scatter of the next, the first and the last beyond it).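

In this assay, the change from phenyl to 4-chlorophenyl, para to a large group, gives a 1.9-fold lower number from compound 3 to compound 4 (0.28 log units; within the scatter), so chloro here cannot be told apart from hydrogen. Compound 4 also cannot be separated from either methoxy compound, with a 1.4-fold lower number from compound 2 to compound 4 (0.14 log units; within the scatter) and a 1.5-fold higher number from compound 1 to compound 4 (0.18 log units; within the scatter), although compound 1 and compound 3 do differ beyond the scatter. No available evidence explains these numbers.

On these data alone, whether a fluoro, nitrile or amine group at this position would move the number beyond the scatter remains open. So does whether chloro elsewhere on this ring would behave the same way.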